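Chalcone analogues against ovarian cancer cells

The source may hold more compounds than are shown below. What is called first, only, known or untested is meant among the compounds shown, and "the series" means these compounds.

Measured so far:
compound 1, `COc1cccc(/C=C/C(=O)c2ccc(OC)c3c2OC(C)(C)C=C3)c1`: 9360 nM
compound 2, `COc1ccc(C(=O)/C=C/c2cccc(Cl)c2)c2c1C=CC(C)(C)O2`: > 10000 nM
compound 3, `COc1ccc(C(=O)/C=C/c2ccc(O)cc2)c2c1C=CC(C)(C)O2`: > 10000 nM

Going by the values given here, in a functional assay on SK-OV-3 cells (Homo sapiens) for antiproliferative activity, read by MTT assay, with a stated time of 24 h (a higher number here means a weaker inhibitor, a lower number a stronger inhibitor), compound 1 gives 9360 nM, the only real number among the three. Compound 2 stands at a limit of the assay. Compound 3 stands at the same limit, which the limit of > 10000 nM in this assay, at which 2 of the 3 values shown sit, notes. Compound 4, `COc1ccc(C(=O)/C=C/c2cc(Cl)ccc2O)c2c1C=CC(C)(C)O2`, differs from compound 1 as 5-chloro-2-hydroxyphenyl in place of 3-methoxyphenyl on a double-bonded chain carbon bound to a double-bonded chain carbon. The step of an at least 1.0-fold higher number from compound 1 to compound 2 (0.02 log units; that floor lies within the scatter) and the step of an at least 1.0-fold higher number from compound 1 to compound 3 (0.02 log units; that floor lies within the scatter) both bear on it, since compound 4 carries a chloro and a hydroxy; each ran toward a limit. Compound 4 is therefore expected at 12000 nM (range 5000 nM to 30000 nM), and the expected step of a 1.3-fold higher number from compound 1 to compound 4 (0.11 log units; within the scatter) likely ends at the limit again.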

Compound 4, half-maximal inhibitory concentration: 6270 nM
Compound 4: middle estimate off by 1.9-fold (0.28 log units), on the high side; measured number inside the range.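

Putting 5-chloro-2-hydroxyphenyl in place of 3-methoxyphenyl at this chain carbon gives a 1.5-fold lower number from compound 1 to compound 4 (0.17 log units; within the scatter), so a ring carrying both chloro and hydroxy still yields a real number. Hydroxy in place of hydrogen on the aromatic carbon gives an at least 1.5-fold lower number from compound 2 to compound 4 (0.20 log units; that floor lies within the scatter), and the swap from 4-hydroxyphenyl gives an at least 1.5-fold lower number from compound 3 to compound 4 (0.20 log units; that floor lies within the scatter); both are floors within the scatter, so neither proves a real gain. Compound 2 and compound 3 each sit at a limit, not a number: the limit of > 10000 nM in this assay, at which 2 of the 4 values shown sit.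

As far as these compounds go, whether an amine or a carboxylic acid on this ring would move the number beyond the scatter remains open.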